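The compounds below may be only part of what the source reports. "The series", "measured", "known", "first", "only" and "open" are said of these compounds alone.

The measured compounds:

- Compound 1, `COc1nc(CC(O)(COCc2ccccc2)COCc2ccccc2)c(C)c(OC)n1`, 2400 nM in a functional assay on HepG2 cells (Homo sapiens) for antiproliferative activity, read by MTT assay, with a stated time of 72 h; a lower number here means a stronger inhibitor, a higher number a weaker inhibitor
- Compound 2, `COCn1c(CC(COCc2ccccc2)COCc2ccccc2)cc(=O)[nH]c1=O`, > 100000 nM in this assay
- Compound 3, `COCn1c(CC(COCc2ccccc2)COCc2ccccc2)c(C)c(=O)[nH]c1=O`, "not determined" (no result reported) in this assay

Among the measured compounds shown here, compound 1 carries a different core from the other two, and in this assay compound 1 gives 2400 nM, the only plain number in the set. For compound 2 the value of > 100000 nM is a limit of the assay, not a number. Compound 3 shares the core of compound 2 and adds a methyl to it; for compound 3 no result was reported, so it stands nowhere among the numbers shown. One of the three values sits at the limit, as the limit of > 100000 nM in this assay, at which 1 of the 3 values shown sits, records, and no step between two measured compounds is shown.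

Compound 4, `COCn1c(CC(O)COCc2ccccc2)c(C)c(=O)[nH]c1=O`, differs from compound 3 by hydroxy in place of (benzyloxy)methyl on a saturated chain carbon bound to two saturated chain carbons. For the measured compounds named here, with no measured step to lean on, the size and direction of this step are open; it may fall within the scatter or well beyond it. Compound 4 is expected to give about 40000 nM in this assay, with a range from 5000 nM to 200000 nM, and a fair chance that only a limit is reported.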

Compound 4, half-maximal inhibitory concentration: > 100000 nM
Compound 4: no number, only a limit; the forecaster's own chance of this, stated with the estimate: 50%; middle value at least 2.5-fold (0.39 log units) from the limit.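

In this assay compound 4 gives > 100000 nM, a limit and not a number. Among the compounds shown here, compound 3 has no number to set against it, so no step between the two can be read. What hydroxy in place of (benzyloxy)methyl does to activity stays open, with limits now common in the set: the limit of > 100000 nM in this assay, at which 2 of the 4 values shown sit.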